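Working notes: methoxy for fluoro, applied a second time

The source may report more compounds than this note shows. Statements on the series, on what has been measured and on what is new or still open speak of the compounds shown alone.

Measured so far in a functional assay on MCF7 cells (Homo sapiens) for cytotoxicity, read by MTT assay, with a stated time of 2 days, tested at 10 uM; a lower number here means a stronger effect, a higher number a weaker effect of the compound at the concentration tested:
compound 1 `CC(=O)c1cc(-c2ccccc2)cc2cc(-c3ccc(F)cc3)[nH]c12` gives 91.9%.
compound 2 `COc1ccc(-c2cc3cc(-c4ccccc4)cc(C(C)=O)c3[nH]2)cc1` gives 64.5%.
compound 3 `CC(=O)c1cc(/C=C/c2ccc(F)cc2)cc2cc(-c3ccc(F)cc3)[nH]c12` gives 67.4%.

Compound 2 differs from compound 1 by methoxy in place of fluoro on an aromatic carbon. That step gave a number 27.4 percentage points lower from compound 1 to compound 2 (beyond the scatter). Compound 3 differs from compound 1 by 2-(4-fluorophenyl)ethenyl in place of phenyl on an aromatic carbon, a change of the core, and gave a number 24.5 percentage points lower from compound 1 to compound 3 (beyond the scatter). Compound 2 and compound 3 lie within the scatter of each other, so nothing is said about their order.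

Compound 4 `COc1ccc(-c2cc3cc(/C=C/c4ccc(F)cc4)cc(C(C)=O)c3[nH]2)cc1` is not yet measured. It differs from compound 3 by methoxy in place of fluoro on an aromatic carbon, the same change as from compound 1 to compound 2, at a place described in the same words. The earlier step rests on a single pair, so its size is carried over with caution. In this assay the step from compound 3 to compound 4 is estimated as a number 17.4 percentage points lower from compound 3 to compound 4 (beyond the scatter), kept smaller than the earlier one because compound 3 starts from 67.4%. Compound 4 is expected to give 50%, with a range from 30% to 72%.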

Compound 4, a percentage reported as activity, at one concentration (the size of the read-out at that concentration, not a potency): 76.5%
For compound 4 the middle estimate is 26.5 percentage points below the measured one; the measured number lies above the stated range.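

In this assay, methoxy in place of fluoro does not carry over from the core of compound 1 to the core of compound 3, since the new step reads a number 9.1 percentage points higher from compound 3 to compound 4 (within the scatter) and differs from the earlier one: the same change on two cores in this assay, a number 27.4 percentage points lower (beyond the scatter) from compound 1 to compound 2 and a number 9.1 percentage points higher (within the scatter) from compound 3 to compound 4, 36.5 percentage points apart, beyond the scatter of two such steps

Read the other way round, 2-(4-fluorophenyl)ethenyl in place of phenyl gives a number 12 percentage points higher from compound 2 to compound 4 (beyond the scatter), and this step also differs from its counterpart: the same change on two cores in this assay, a number 24.5 percentage points lower (beyond the scatter) from compound 1 to compound 3 and a number 12 percentage points higher (beyond the scatter) from compound 2 to compound 4, 36.5 percentage points apart, beyond the scatter of two such steps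

These four compounds show that the two changes do not add up in this set, but with one reading per compound they do not show why, nor how the changes would behave on any other core.

The compounds shown leave open whether an amine or a carboxylic acid in place of the methoxy would follow compound 2 or compound 4. They also leave open how a longer chain in place of the ethenyl link would behave, and, with readings at a single concentration, how the compounds would compare at any other concentration, where the effect could be stronger or weaker.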